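The source may hold more compounds than are shown below. What is called first, only, known or untested is meant among the compounds shown, and "the series" means these compounds.

Three compounds share one core and differ only at the outer six-membered aromatic ring of carbon only. Compound 3 `COc1cc(Cl)cc(-c2nn(-c3cccc(NC(=O)Nc4cccc(C(F)(F)F)c4)c3)cc2-c2ccncc2)c1` gives 94% in a functional assay on SF-268 cells (Homo sapiens) for inhibition, read by sulforhodamine B assay, with a stated time of 48 h, tested at 0.1 uM; a lower number here means a stronger effect, a higher number a weaker effect of the compound at the concentration tested. Compound 1 `COc1cc(Cl)cc(-c2nn(-c3cccc(NC(=O)Nc4ccc(Cl)c(C(F)(F)F)c4)c3)cc2-c2ccncc2)c1` gives 90% in this assay, and compound 2 `COc1cc(Cl)cc(-c2nn(-c3cccc(NC(=O)Nc4ccc(Cl)c(Cl)c4)c3)cc2-c2ccncc2)c1` gives 95%. The number for compound 3 is the second highest of the three, yet every step among them stays within the scatter: a number 5 percentage points higher from compound 1 to compound 2 (within the scatter), a number 4 percentage points higher from compound 1 to compound 3 (within the scatter) and a number 1 percentage points lower from compound 2 to compound 3 (within the scatter). In other words, all three show a weak effect of about the same size at this concentration.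

Compound 4 `COc1cc(Cl)cc(-c2nn(-c3cccc(NC(=O)c4cccc(C(F)(F)F)c4)c3)cc2-c2ccncc2)c1` differs from compound 3 by 3-(trifluoromethyl)phenyl in place of (3-(trifluoromethyl)phenyl)amino on a carbonyl carbon. For the measured compounds named here, none of the measured steps touched the carbonyl carbon or its amide-type nitrogen; each swapped a substituent on the outer ring, and each stayed within the scatter. No step therefore bears directly on this change, and the data give no reason to expect a movement beyond the scatter, so the expected step is a number 1 percentage points lower from compound 3 to compound 4 (within the scatter). Compound 4 is thus estimated to give about 93% in this assay, between 80% and 104%.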

Compound 4, a percentage reported as activity, at one concentration (the size of the read-out at that concentration, not a potency): 100%
For compound 4 the middle estimate is 7 percentage points below the measured one; the range from low to high includes it.
By their numbers in this assay, from the lowest: compounds 1, 3, 2 and 4 (each within the scatter of the next).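

For the compounds shown here, this is the first change at the carbonyl carbon rather than on the outer ring: the amino nitrogen and its hydrogen-bond donor go, while the 3-(trifluoromethyl)phenyl group stays. In this assay this gives a number 6 percentage points higher from compound 3 to compound 4 (within the scatter) and the two comparisons that also change the outer ring give a number 5 percentage points higher from compound 2 to compound 4 (within the scatter) and a number 10 percentage points higher from compound 1 to compound 4 (within the scatter) so at this single concentration the loss of that nitrogen has no effect that can be told from scatter. Nothing available explains this result.

Going by these compounds, with every number this close, it stays open whether the link matters at a concentration where the effect is larger. Also open, on these data alone, is how the series would read with a sulfonamide or a plain amine as the link, or with a carboxylic acid on the outer ring.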